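A Replacement of the Amide Substituent on a Nitroaryl Piperidine Amide

This account rests on a few compounds, and the source may have more. Where it says the series, first, only, none or still open, it means among the compounds named here.

Compound 1 `CN(Cc1ccccc1F)C(=O)C1CCN(C(=O)c2ccc(S(C)(=O)=O)c([N+](=O)[O-])c2)CC1` carries a (2-fluorobenzyl)(methyl)amino group on a carbonyl carbon whose other neighbour is a saturated ring carbon. In an assay on isolated protein for inhibition of thyroid hormone receptor beta (Homo sapiens), read by fluorescence polarization (a lower number here means a stronger inhibitor, a higher number a weaker inhibitor), compound 1 gives > 60000 nM, which is a limit of the assay rather than a number. Two related compounds share this outcome. Compound 2 `CS(=O)(=O)c1ccc(C(=O)NCC(=O)N2CCCCC2)cc1[N+](=O)[O-]` gives > 60000 nM in this assay, again a limit. Compound 3 `CC1CCN(C(=O)CN(C)C(=O)c2ccc(S(C)(=O)=O)c([N+](=O)[O-])c2)CC1` gives > 60000 nM in this assay, also a limit. Within the data shown here, all three sit at the limit of > 60000 nM in this assay, at which 3 of the 3 values shown sit, so none of them stands on a numbered scale and no step between them can be sized.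

Compound 4 `CC(C)N(C(=O)C1CCN(C(=O)c2ccc(S(C)(=O)=O)c([N+](=O)[O-])c2)CC1)C(C)C` has not been measured in this assay. It differs from compound 1 in one place: diisopropylamino in place of (2-fluorobenzyl)(methyl)amino on a carbonyl carbon. Compound 1 shows > 60000 nM, a limit and nothing more. With no numbered value at the start, the step expected from compound 1 to compound 4 is a step that the limit leaves unreadable from compound 1 to compound 4, understood as none beyond the scatter, with compound 4 expected to remain at the limit as well. Compound 4 is therefore estimated at 100000 nM, with a range from 30000 nM to 300000 nM, and most likely reported as a limit once more.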

Compound 4, half-maximal inhibitory concentration: > 60000 nM
Compound 4: only a limit was reported; the forecaster's own chance of this, stated with the estimate: 85%; the middle value does not contradict the limit.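

No step can be read between compound 1 and compound 4, since both are reported only as limits in this assay: the limit of > 60000 nM in this assay, at which 4 of the 4 values shown sit.

The compounds shown leave open how diisopropylamino and (2-fluorobenzyl)(methyl)amino compare on a carbonyl carbon, and which change to the shared core, if any, would give a numbered value in this assay.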